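The source may report more compounds than this note shows. Statements on the series, on what has been measured and on what is new or still open speak of the compounds shown alone.

In a functional assay on MDA-MB-231 cells (Homo sapiens) for inhibition, read by CCK-8 assay, with a stated time of 48 h (on this read-out lower numbers stand for stronger inhibition of growth and higher numbers for weaker inhibition of growth), compound 1 `CN1CCN(c2ccc(Nc3ncc(Cl)c(NCc4ccc(C(F)(F)F)cc4)n3)nc2)CC1` gives 19100 nM and compound 2 `Cc1ccc(CNc2nc(Nc3ccc(N4CCN(C)CC4)cn3)ncc2Cl)cc1` gives 18600 nM. Among the compounds with values here, these two values lie within the scatter of each other, so compound 2 stands level with the only other compound measured. Compound 3 `COc1cccc(CNc2nc(Nc3ccc(N4CCN(C)CC4)cn3)ncc2Cl)c1` keeps the shared core and changes one group: 3-methoxyphenyl in place of 4-methylphenyl on a saturated chain carbon bound to a nitrogen on an aromatic ring. Put simply, 3-methoxyphenyl takes the place of 4-methylphenyl on a saturated chain carbon bound to a nitrogen on an aromatic ring. Within the data shown here, only one measured step bears on this change, a 1.0-fold lower number from compound 1 to compound 2 (0.01 log units; within the scatter), where methyl replaced trifluoromethyl on an aromatic carbon, and it stayed within the scatter. Among the measured compounds shown here, no measured compound carries the 3-methoxybenzyl group, so that evidence is indirect. No shift beyond the scatter is therefore expected in this assay, and the estimated step is a 1.0-fold lower number from compound 2 to compound 3 (0.01 log units; within the scatter). The expected value for compound 3 is 18000 nM, within an estimated range of 8000 nM to 40000 nM.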

Compound 3, concentration for 50% growth inhibition: 20300 nM
Compound 3: the middle estimate sits 1.1-fold (0.05 log units) below what was measured, within the range that was stated.
By their numbers in this assay, from the lowest: compounds 2, 1 and 3 (each within the scatter of the next).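

In this assay, within the data shown here, the earlier compounds compared only 4-(trifluoromethyl)phenyl and 4-methylphenyl, while compound 3 carries 3-methoxyphenyl, with an added oxygen and one hydrogen-bond acceptor. Even so, the numbers stay within the scatter (a 1.1-fold higher number from compound 2 to compound 3 (0.04 log units; within the scatter)) and (a 1.1-fold higher number from compound 1 to compound 3 (0.03 log units; within the scatter)), so none of the three aryl groups at this place separates from the others in this assay. No measured evidence on any property of these groups bears on this result.

The three compounds leave open whether any group on this phenyl ring can move the number beyond the scatter, for example an amine or a carboxylic acid. They also leave open whether a longer chain between the ring and the nitrogen would do so.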